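Adding an Acid Chain to a Potent Compound

This account rests on a few compounds, and the source may have more. Where it says the series, first, only, none or still open, it means among the compounds named here.

In a functional assay on DU-145 cells (Homo sapiens) for cytotoxicity, read by trypan blue exclusion, with a stated time of 96 h (a lower number here means a stronger inhibitor, a higher number a weaker inhibitor), compound 1 (`COc1cc(OC)c(/C=C/S(=O)(=O)Nc2ccc(F)c(N)c2)c(OC)c1`) gives 10000 nM, while compound 2 (`COc1cc(OC)c(/C=C/S(=O)(=O)Nc2ccc(OC)c(N)c2)c(OC)c1`) gives 5 nM, the lower of the two numbers. Compound 3 (`COc1ccc(NS(=O)(=O)/C=C/c2c(OC)cc(OCCCC(=O)O)cc2OC)cc1N`) differs from compound 2 by 2-carboxyethyl in place of hydrogen on a saturated chain carbon bound to an oxygen on an aromatic ring. Going by the values given here, the only measured step, a 2000-fold lower number from compound 1 to compound 2 (3.30 log units; beyond the scatter), is large but is a different change, methoxy in place of fluoro, so it shows only that one swap can matter greatly here. With compound 2 at 5 nM, a higher number is the likelier outcome in this assay, and the estimated move is a 12-fold higher number from compound 2 to compound 3 (1.08 log units; beyond the scatter). For compound 3, the expected value is 60 nM, within an estimated range of 8 nM to 600 nM.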

Compound 3, half-maximal inhibitory concentration: 10000 nM
Compound 3: middle estimate off by 170-fold (2.22 log units), on the low side; the whole stated range lies below it.
By their numbers in this assay, from the lowest: compound 2; then compounds 1 and 3 (each within the scatter of the next).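

Replacing methoxy with 3-carboxypropoxy on the aromatic ring gives a 2000-fold higher number from compound 2 to compound 3 (3.30 log units; beyond the scatter) in this assay and so marks this as a second place where one change can nearly abolish the effect on these cells. The earlier pair differed only at another place on the shared core, so it said nothing about this one. Nothing available explains the drop.

The compounds shown leave open whether the chain length or its acid end matters. A plain butoxy chain, a methyl ester or an amine at the chain end could separate the two.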